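A few compounds are considered here, and "the series" means these few. Any claim that something is new, unique, unknown or untested is made for them only; others in the source may bear on it.

Compound 2 `CCCCc1nc(-c2cnc3ccc(-c4ccc(N)cc4)cc3c2)no1` and compound 1 `CCCc1nc(-c2cnc3ccc(-c4ccc(N)cc4)cc3c2)no1` share one core and differ only in a side chain. In a functional assay on RD cells (Homo sapiens) for inhibition, read by luminescence and ATP content, with a stated time of 72 h (a higher number here means that more compound is tolerated, a lower number that less compound is tolerated), compound 2 reaches only the limit > 2500 nM. In this assay compound 1 likewise reaches only the limit > 800 nM. The change between them is hydrogen in place of methyl on a saturated chain carbon, three bonds along the chain from an aromatic carbon, and the step that the two limits leave unreadable from compound 2 to compound 1 cannot be sized, as both values are limits.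

Compound 3 `CCCCc1ccc(-c2ccc3ncc(-c4noc(C)n4)cc3c2)cc1` carries a different core, and how its core differs from that of compound 2 is not broken down here. In this assay compound 3 reaches only the limit > 2500 nM. Compound 4 `CCCc1ccc(-c2ccc3ncc(-c4noc(C)n4)cc3c2)cc1` differs from compound 3 by the same change, (hydrogen in place of methyl on a saturated chain carbon, three bonds along the chain from an aromatic carbon), at the same place.

For compound 4 the step that the limit leaves unreadable from compound 3 to compound 4 is expected, resting on (the limit of > 2500 nM in this assay, at which 2 of the 3 values shown sit). Compound 4 is expected to give about 3000 nM, between 1500 nM and 8000 nM.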

Compound 4, half-maximal cytotoxic concentration: > 7400 nM
Compound 4: only a limit was reported (the forecaster's own chance of this, stated with the estimate: 80%); middle value at least 2.4-fold (0.39 log units) from the limit.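

For the compounds shown here, compound 3 and compound 4 each reach only a limit, so no step between them can be read. The compounds shown leave open whether the change from butyl to propyl shifts the result in this assay at all.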